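Methoxy in place of chloro on the aryl ether of compound 3

The source may report more compounds than this note shows. Statements on the series, on what has been measured and on what is new or still open speak of the compounds shown alone.

Compound 1 `Cc1ncc(OCCCCOc2ccc(C(=O)CC(C)(C)C)c(O)c2C)cc1C(=O)O` gives 28 nM in an assay for positive allosteric modulation of metabotropic glutamate receptor 2 (Rattus norvegicus); a higher number here means that more compound is needed for the effect, a lower number that less compound is needed.
Compound 2 `Cc1c(OCCCCOc2cncc(C(=O)O)c2)ccc(C(=O)CC(C)(C)C)c1O` gives 490 nM in this assay.
Compound 3 `Cc1c(OCCCCOc2ccc(Cl)c(C(=O)O)c2)ccc(C(=O)CC(C)(C)C)c1O` gives 87 nM in this assay.

Compound 3 holds the second highest of the three numbers: compound 1 sits nearest, with a 3.1-fold higher number from compound 1 to compound 3 (0.49 log units; beyond the scatter), and compound 2 sits furthest, with a 5.6-fold lower number from compound 2 to compound 3 (0.75 log units; beyond the scatter). Compound 4 `COc1ccc(OCCCCOc2ccc(C(=O)CC(C)(C)C)c(O)c2C)cc1C(=O)O` differs from compound 3 in a single place: methoxy in place of chloro on an aromatic carbon.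

For the measured compounds named here, no measured step exchanges chloro for methoxy, so the expectation rests on neighbouring evidence. The step of an 18-fold higher number from compound 1 to compound 2 (1.24 log units; beyond the scatter) shows that a small group on the aromatic ring carrying the carboxy group matters a great deal; compound 4 keeps a group there, merely a different one. The steps of a 3.1-fold higher number from compound 1 to compound 3 (0.49 log units; beyond the scatter) and a 5.6-fold lower number from compound 2 to compound 3 (0.75 log units; beyond the scatter) concern a change of the whole ring and bear only loosely on the present step. A small step in this assay, within or close to the scatter and in either direction, is therefore expected, written as a 1.2-fold lower number from compound 3 to compound 4 (0.09 log units; within the scatter). Compound 4 is expected to give about 70 nM in this assay, with a range from 25 nM to 200 nM.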

Compound 4, half-maximal effective concentration: 13 nM
Compound 4: the middle estimate sits 5.4-fold (0.73 log units) above what was measured, outside the stated range (below it).
By their numbers in this assay, from the lowest: compound 4; then compound 1; then compound 3; then compound 2.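

In this assay, the exchange of chloro for methoxy, on an aromatic carbon ortho to a carboxy group and para to a large group, gives a 6.7-fold lower number from compound 3 to compound 4 (0.83 log units; beyond the scatter). For the compounds shown here, the earlier step of an 18-fold higher number from compound 1 to compound 2 (1.24 log units; beyond the scatter) compared methyl with hydrogen on a different ring and showed only that removing a small group there can cost a great deal; the new step shows that, with a group kept in place, the choice between two small groups also moves the number beyond the scatter. Chloro, with one heavy atom and no hydrogen-bond acceptor, gives way here to methoxy, with two heavy atoms and one hydrogen-bond acceptor, but no measurement offered here accounts for the difference.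

The compounds shown leave open how hydrogen, fluoro, methyl or ethoxy would compare with chloro and methoxy on this same aromatic carbon, so the size of the effect of having any group there remains unknown for this ring. They also leave open whether methoxy in place of the methyl group of compound 1 would move the number in the same direction.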